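Methoxy at the Ring Carbon of the Shared Core

The source may report more compounds than this note shows. Statements on the series, on what has been measured and on what is new or still open speak of the compounds shown alone.

Measured so far in a functional assay on MGC-803 cells (Homo sapiens) for antiproliferative activity, read by CCK-8 assay, with a stated time of 72 h; on this read-out lower numbers stand for stronger inhibition and higher numbers for weaker inhibition:
compound 1, `CC1(O)CCN(c2ccn3c(-c4ccc(NC(=O)c5ccc([N+](=O)[O-])o5)cc4)cnc3c2)CC1`: 3100 nM
compound 2, `O=C(Nc1ccc(-c2cnc3cc(Cl)ccn23)cc1)c1ccc([N+](=O)[O-])o1`: 4620 nM
compound 3, `O=C(Nc1ccc(-c2cnc3ccccn23)cc1)c1ccc([N+](=O)[O-])o1`: 590 nM

Compound 3 gives the lowest number of the three, and both of its gaps to the others lie beyond the usual scatter: a 5.3-fold lower number from compound 1 to compound 3 (0.72 log units; beyond the scatter) and a 7.8-fold lower number from compound 2 to compound 3 (0.89 log units; beyond the scatter). On these numbers compound 3 is the strongest inhibitor of the set.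

Compound 4, `COc1ccn2c(-c3ccc(NC(=O)c4ccc([N+](=O)[O-])o4)cc3)cnc2c1`, has not yet been measured. It differs from compound 3 in one place: methoxy in place of hydrogen on an aromatic carbon. This is the same aromatic carbon that carries the 4-hydroxy-4-methylpiperidin-1-yl group in compound 1 and the chloro in compound 2, and in both of those compounds the carbon bearing a group goes with a higher number than the bare hydrogen of compound 3. Both steps bear on the change, and both were modest but beyond the scatter. A methoxy group is a third, smaller substituent at that carbon, so a higher number than compound 3 is expected for compound 4, likely of a similar modest size: a 3.4-fold higher number from compound 3 to compound 4 (0.53 log units; beyond the scatter). The estimate for compound 4 in this assay is 2000 nM, with a range from 700 nM to 6000 nM.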

Compound 4, half-maximal inhibitory concentration: 860 nM
Beside the measured number, compound 4's estimate is 2.3-fold (0.37 log units) above it; the measured number falls inside the stated range.
By their numbers in this assay, from the lowest: compounds 3 and 4 (each within the scatter of the next); then compounds 1 and 2 (each within the scatter of the next).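

In this assay, the step of a 1.5-fold higher number from compound 3 to compound 4 (0.16 log units; within the scatter) shows that this aromatic carbon, opposite the ring nitrogen, can carry a methoxy group with no change that stands clear of the usual scatter, so a group here does not always come with a higher number, as compounds 1 and 2 alone might have suggested. What sits on this carbon still matters, since the same carbon gives a 5.4-fold lower number from compound 2 to compound 4 (0.73 log units; beyond the scatter) when methoxy replaces chloro and a 3.6-fold lower number from compound 1 to compound 4 (0.56 log units; beyond the scatter) when methoxy replaces 4-hydroxy-4-methylpiperidin-1-yl, and both of these steps lie beyond the scatter. No measurement at hand offers a reason why methoxy parts from the other two groups in this way.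

The compounds shown leave open whether a longer chain such as ethoxy, an amine such as dimethylamino or a carboxylic acid on this carbon would stay within the scatter of compound 3 or move toward the higher number of compound 2. They also leave open whether methoxy would be met in the same way on the other carbons of this six-membered aromatic ring.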